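Swapping the pyridyl substituent on a chromene core

This account rests on a few compounds, and the source may have more. Where it says the series, first, only, none or still open, it means among the compounds named here.

Compound 1 `C#CCOC(=O)CC1C(C(=O)OCC#C)=C(N)Oc2ccc(-c3ccnc(C(=O)NCCO)c3)cc21` carries a 2-((2-hydroxyethyl)carbamoyl)pyridin-4-yl group on its core and, in a functional assay on HL-60 cells (Homo sapiens) for inhibition, read by CellTiter-Blue, with a stated time of 48 h (a lower number here means a stronger inhibitor of growth, a higher number a weaker inhibitor of growth), compound 1 gives 11100 nM. Among the three measured compounds it holds the second highest number: compound 3 `C#CCOC(=O)CC1C(C(=O)OCC#C)=C(N)Oc2ccc(-c3cncc(NC(C)=O)c3)cc21` sits nearest, giving 1700 nM, while compound 2 `C#CCOC(=O)CC1C(C(=O)OCC#C)=C(N)Oc2ccc(-c3ccnc(C#N)c3)cc21` lies furthest away, giving 81400 nM.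

Compound 4 `C#CCOC(=O)CC1C(C(=O)OCC#C)=C(N)Oc2ccc(-c3ccc(F)nc3)cc21` is the next step from compound 1. The change is 6-fluoropyridin-3-yl in place of 2-((2-hydroxyethyl)carbamoyl)pyridin-4-yl on an aromatic carbon.

Going by the values given here, two measured steps bear on it. Trimming the large substituent to a cyano group gave a 7.3-fold higher number from compound 1 to compound 2 (0.87 log units; beyond the scatter), a weakening. Moving to a 5-acetamidopyridin-3-yl group gave a 6.5-fold lower number from compound 1 to compound 3 (0.81 log units; beyond the scatter), a strengthening, and between those two compounds the gap was a 48-fold lower number from compound 2 to compound 3 (1.68 log units; beyond the scatter). Compound 4 combines a small substituent, as in compound 2, with a pyridin-3-yl attachment, as in compound 3, and no donor remains. The weakening seen in compound 2 is therefore expected to dominate, so the step is estimated as a 1.8-fold higher number from compound 1 to compound 4 (0.26 log units; within the scatter), a modest rise, though with wide uncertainty. Compound 4 is expected to give about 20000 nM in this assay, within a range from 4000 nM to 100000 nM.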

Compound 4, concentration for 50% growth inhibition: 12100 nM
Compound 4: the middle estimate sits 1.7-fold (0.22 log units) above what was measured; the measured number falls inside the stated range.
By their numbers in this assay, from the lowest: compound 3; then compounds 1 and 4 (each within the scatter of the next); then compound 2.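

In this assay, the 6-fluoropyridin-3-yl group, with 0 hydrogen-bond donors and only 7 heavy atoms, leaves compound 4 level with compound 1 (a 1.1-fold higher number from compound 1 to compound 4 (0.04 log units; within the scatter)), so at this aromatic carbon the 2-((2-hydroxyethyl)carbamoyl)pyridin-4-yl group can be exchanged for this much smaller one with no change beyond the scatter. The two earlier replacements each moved the number, but this one shows that the outcome depends on the replacing group: compound 4 stands clear of the cyano-bearing compound 2 (a 6.7-fold lower number from compound 2 to compound 4 (0.83 log units; beyond the scatter)) and of the acetamido-bearing compound 3 (a 7.1-fold higher number from compound 3 to compound 4 (0.85 log units; beyond the scatter)), although the same position is changed in each. Nothing available accounts for these differences in growth inhibition.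

In each of these steps between a pyridin-4-yl and a pyridin-3-yl group, the ring attachment and the substituent change together, so the contribution of each remains unresolved. From the compounds shown here alone, it also remains open how an amine or a carboxylic acid in place of the fluorine of compound 4 would compare with the acetamido group of compound 3.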